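Shrinking the aromatic-nitrogen substituent: cyclobutyl to methyl

The source may hold more compounds than are shown below. What is called first, only, known or untested is meant among the compounds shown, and "the series" means these compounds.

Compound 1 `CN(C)C(=O)CN1CCC(c2cc3c(-c4ccc(=O)n(CCC5CCOCC5)c4)ccnc3[nH]2)CC1` is cleared at 19 uL/min in an ADME assay on microsomes from liver (Homo sapiens) for metabolic stability; on this read-out higher numbers stand for fast clearance and lower numbers for slow clearance. Compound 2 `CN(C)C(=O)CN1CCC(c2cc3c(-c4ccc(=O)n(C5CCC5)c4)ccnc3[nH]2)CC1` carries cyclobutyl in place of 2-(oxan-4-yl)ethyl on the aromatic nitrogen, and that change gave an at least 6.3-fold lower number from compound 1 to compound 2 (0.80 log units; beyond the scatter). In this assay compound 2 reports only a limit, < 3 uL/min, so its true position is open (the limit of < 3 uL/min in this assay, at which 1 of the 2 values shown sits). Compound 3 `CN(C)C(=O)CN1CCC(c2cc3c(-c4ccc(=O)n(C)c4)ccnc3[nH]2)CC1` differs from compound 2 by methyl in place of cyclobutyl on an aromatic nitrogen. Within the data shown here, only the step from compound 1 to compound 2 bears on this change, and it pointed downward; since compound 2 already sits at the limit, no step beyond the scatter is expected for compound 3 a number no lower from compound 2 to compound 3 (the limit leaves the size open). Compound 3 is expected to give 3 uL/min, within 1.5 uL/min to 8 uL/min, most likely again reported as a limit.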

Compound 3, intrinsic clearance in a liver preparation (reported as CLH), per the amount of preparation that the assay uses in the Homo sapiens assay: < 3 uL/min
Compound 3 was reported as a limit; the forecaster's own chance of this, stated with the estimate: 60%; the middle value lies on the limit itself.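

In the Homo sapiens assay, methyl in place of the larger group gives an at least 6.3-fold lower number from compound 1 to compound 3 (0.80 log units; beyond the scatter), so the lower number seen with cyclobutyl also holds for a second small group. Compound 2 and compound 3 both stand as limits, so the step between them cannot be read: the limit of < 3 uL/min in the Homo sapiens assay, at which 2 of the 3 values shown sit.

In a physicochemical assay for lipophilicity, using the shake flask method, measured as octanol-water partition, at pH 7.4 (on this read-out higher numbers stand for higher lipophilicity and lower numbers for lower lipophilicity), compound 2 gives 1.9 and compound 3 gives 1.1, so this change separates the two compounds on that read-out, while clearance does not.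

As far as these compounds go, how far the true clearance of either compound lies from the limit stays open. Also open, from the compounds shown here alone, is how a chain ending in an amine or a carboxylic acid on this aromatic nitrogen would read in the Homo sapiens assay.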